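A few compounds are considered here, and "the series" means these few. Any claim that something is new, unique, unknown or untested is made for them only; others in the source may bear on it.

Measured so far in a functional assay on MDA-MB-468 cells (Homo sapiens) for cytotoxicity, read by sulforhodamine B assay, with a stated time of 48 h, tested at 0.01 uM; a higher number here means a weaker effect of the compound at the concentration tested, a lower number a stronger effect:
- compound 1 `Cc1cc(O)cc(-c2nn(CC#N)cc2-c2ccnc(-c3ccc(Oc4ccccc4)cc3)c2)c1`: 85%
- compound 2 `COc1cc(C)cc(-c2nn(CC#N)cc2-c2ccnc(-c3ccc(N(C)C)cc3)c2)c1`: 74%

Compound 2 stands at the lower of the two numbers, 74%; compound 1 sits higher, at 85%, a gap beyond the usual scatter. The two differ in more than one place, so the pair shows only its two values.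

Compound 3 `Cc1cc(O)cc(-c2nn(CC#N)cc2-c2ccnc(-c3ccc(N(C)C)cc3)c2)c1` differs from compound 2 by hydrogen in place of methyl on an oxygen on an aromatic ring. Within the data shown here, no measured pair isolates this change. The expected step of a number 2 percentage points higher from compound 2 to compound 3 (within the scatter) is therefore small, not beyond the scatter in either direction. Compound 3 is estimated at 76%, with a range from 60% to 90%.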

Compound 3, a percentage reported as activity, at one concentration (the size of the read-out at that concentration, not a potency): 91%
Estimate against measurement, compound 3: 15 percentage points below; measured number above the stated range.
By their numbers in this assay, from the lowest: compound 2; then compounds 1 and 3 (each within the scatter of the next).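

In this assay, among these compounds, the change from methoxy to hydroxy gives the first single-change step, a number 17 percentage points higher from compound 2 to compound 3 (beyond the scatter), so the methyl on this oxygen matters and the methoxy compound has the stronger effect. With the hydroxy group held constant, dimethylamino in place of phenoxy on an aromatic carbon gives a number 6 percentage points higher from compound 1 to compound 3 (within the scatter), so this swap shows no separable change. Nothing available explains the methoxy step.

Going by these compounds, it remains open whether an ethoxy group or a longer alkoxy chain on this oxygen, or an amine in place of it, would match or go beyond methoxy. On these data alone, whether the methoxy step carries over to compounds with phenoxy in place of dimethylamino also remains open.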